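Working notes: a chain group exchanged for phenyl

The source may report more compounds than this note shows. Statements on the series, on what has been measured and on what is new or still open speak of the compounds shown alone.

Compound 1 `Cc1ccc2nc(NC(=O)/C=C/OC3=CC=C3)sc2c1` stands highest of the three measured compounds in a functional assay on the whole organism (Hindlimb, strain albino) with Mus musculus as the target, in the maximal electroshock model, with a stated time of 0.5 h (a lower number here means that less compound is needed, a higher number that more compound is needed for the effect), at 505 umol/kg and so needs the most compound for the effect. Compound 3 `O=C(/C=C/c1ccc(Cl)cc1)Nc1nc2ccc(Cl)cc2s1` lies nearest to it at 204 umol/kg and compound 2 `COc1ccc(C2CC(Nc3nc4ccc([N+](=O)[O-])cc4s3)=NN2C(C)=O)cc1` lies furthest at 145 umol/kg with both gaps beyond the scatter.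

Compound 4 `Cc1ccc2nc(NC(=O)/C=C/c3ccccc3)sc2c1` has not yet been measured. The structural change from compound 1 to compound 4 is a group of 6 heavy atoms (6 carbon; one six-membered aromatic ring of carbon only) in place of a group of 5 heavy atoms (4 carbon, 1 oxygen; one four-membered non-aromatic ring of carbon only), on a double-bonded chain carbon bound to a double-bonded chain carbon and the phenyl enters on a double-bonded chain carbon bound to a double-bonded chain carbon. Among the compounds with values here, no measured pair isolates this change, so its size cannot be read directly from the data.

A shift toward lower numbers is expected since compound 1 at 505 umol/kg sits at the top of the measured range. The expected change is a 2.1-fold lower number from compound 1 to compound 4 (0.32 log units; beyond the scatter) and this estimated step is modest, close to the scatter. For compound 4 the estimated value is 240 umol/kg with an expected range from 110 umol/kg to 520 umol/kg in this series.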

Compound 4, dose for half-maximal effect: 380 umol/kg
For compound 4 the middle estimate is 1.6-fold (0.20 log units) below the measured one; measured number inside the range.
By their numbers in this assay, from the lowest: compounds 2, 3, 4 and 1 (each within the scatter of the next, the first and the last beyond it).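

In this assay, within the data shown here, the exchange on the double-bonded chain carbon gives a 1.3-fold lower number from compound 1 to compound 4 (0.12 log units; within the scatter), the first direct reading of a change at this position. Phenyl and the group of 5 heavy atoms with its four-membered non-aromatic ring cannot be told apart here, so neither that ring nor its oxygen is shown to matter for the number at this place. Nothing measured bears on why the two groups give so similar a result.

Going by these compounds, whether a different kind of group at this place, such as an amine, a carboxylic acid or a longer chain, would move the number beyond the scatter remains open. On these data alone, the other compounds differ from these two in more than one place, so no further step can be read, and whether this result carries over to other substituents on the shared core also stays open.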